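This account rests on a few compounds, and the source may have more. Where it says the series, first, only, none or still open, it means among the compounds named here.

Measured compounds:
compound 1 `Oc1ccc(-c2cc(-c3cccs3)nc(-c3ccccc3Cl)c2)cc1`, giving 2.2% in an assay on isolated protein for inhibition of DNA topoisomerase 1 (Homo sapiens), with a stated time of 30 min, tested at 100 uM; a higher number here means a stronger effect of the compound at the concentration tested, a lower number a weaker effect;
compound 2 `Oc1cccc(-c2cc(-c3cccnc3)nc(-c3ccccc3Cl)c2)c1`, giving 0% in this assay;
compound 3 `Oc1ccc(-c2cc(-c3cccnc3)nc(-c3cccc(Cl)c3)c2)cc1`, giving 55.2% in this assay.

Compound 3 has the highest of these three numbers in this assay; compound 1 lies nearest, though already beyond the scatter below it, and compound 2 lies furthest. Compound 4 `Oc1ccc(-c2cc(-c3cccnc3)nc(-c3ccccc3Cl)c2)cc1` has the same atoms as compound 3, joined differently: 2-chlorophenyl in place of 3-chlorophenyl on an aromatic carbon. Among the compounds with values here, no single-change step between measured compounds is at hand, so the direction is read from the other two compounds, both of which carry a 2-chlorophenyl group and sit low. The step of a number 45.2 percentage points lower from compound 3 to compound 4 (beyond the scatter) is expected to be large and downward, because compound 1 with its 2-chlorophenyl group gives 2.2% and compound 2 with the same group gives 0%. Compound 4 is estimated at 10%, within 0% to 35%.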

Compound 4, a percentage reported as inhibition, at one concentration (the size of the read-out at that concentration, not a potency): 0.9%
Estimate against measurement, compound 4: 9.1 percentage points above, and the stated range covers the measured number.
By their numbers in this assay, from the lowest: compounds 2, 4 and 1 (each within the scatter of the next); then compound 3.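

In this assay, within the data shown here, 2-chlorophenyl in place of 3-chlorophenyl next to the ring nitrogen gives a number 54.3 percentage points lower from compound 3 to compound 4 (beyond the scatter), the first single-change reading at this position. With 2-chlorophenyl present, neither 4-hydroxyphenyl in place of 3-hydroxyphenyl, a number 0.9 percentage points higher from compound 2 to compound 4 (within the scatter), nor pyridin-3-yl in place of thiophen-2-yl, a number 1.3 percentage points lower from compound 1 to compound 4 (within the scatter), separates the compounds beyond the scatter. Nothing measured here accounts for the drop.

On these data alone, whether those two changes would also do little alongside 3-chlorophenyl remains open. So does what a 4-chlorophenyl group, or an aminophenyl group, would give at this position.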